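Oxindole series: chloro removal from compound 1

The source may report more compounds than this note shows. Statements on the series, on what has been measured and on what is new or still open speak of the compounds shown alone.

Compound 1 `O=C1Nc2ccc(Cl)cc2/C1=C\c1c(Cl)n(CCCc2ccccc2)c2ccccc12` gives 8910 nM in a functional assay on NSCLC cells (Homo sapiens) for cytotoxicity, with a stated time of 48 h; on this read-out lower numbers stand for stronger inhibition of growth and higher numbers for weaker inhibition of growth. Its number is the lowest of the three measured, but compound 3 `COc1cc2c(c(OC)c1OC)/C(=C\c1c(Cl)[nH]c3ccccc13)C(=O)N2` at 9120 nM and compound 2 `COc1cc2c(/C=C3/C(=O)Nc4cccc(Cl)c43)c(Cl)n(Cc3cc(OC)c(OC)c(OC)c3)c2cc1C` at 12000 nM both sit within the scatter of it, so the three cannot be separated. Compound 4 `O=C1Nc2ccccc2/C1=C\c1c(Cl)n(CCCc2ccccc2)c2ccccc12` has not yet been measured; it differs from compound 1 by hydrogen in place of chloro on an aromatic carbon. Among the measured compounds shown here, no pair among the measured compounds isolates this change, so it cannot be read off directly. The three measured numbers cluster closely for rather different substitution, so the expected step of a 1.1-fold higher number from compound 1 to compound 4 (0.05 log units; within the scatter) is small, with no direction beyond the scatter. Compound 4 is therefore estimated at 10000 nM, in the range 4000 nM to 25000 nM.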

Compound 4, concentration for total growth inhibition: 72400 nM
For compound 4 the middle estimate is 7.2-fold (0.86 log units) below the measured one; the whole stated range lies below it.
By their numbers in this assay, from the lowest: compounds 1, 3 and 2 (each within the scatter of the next); then compound 4.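

Among the compounds shown here, this is the first one-place comparison: in this assay, hydrogen in place of chloro on this aromatic carbon gives an 8.1-fold higher number from compound 1 to compound 4 (0.91 log units; beyond the scatter). The close values of compound 1, compound 2 and compound 3 therefore do not mean that this position is indifferent, and here the chloro is tied to the lower number. Nothing available explains the step.

From the compounds shown here alone, whether fluoro, bromo or methoxy on this carbon would match chloro remains open. So does whether the step would persist with a shorter chain in place of the one carried by compound 1.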